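Methoxy to Methyl, Examined Twice on One Core

The source may hold more compounds than are shown below. What is called first, only, known or untested is meant among the compounds shown, and "the series" means these compounds.

Of the compounds shown here, three built on one shared core have been tested in a functional assay on MCF7 cells (Homo sapiens) for inhibition, read by MTT assay, with a stated time of 72 h; a higher number here means a weaker inhibitor, a lower number a stronger inhibitor. Compound 1 `Cc1ccc2c(c1)/C(=N/NC(=S)N1CCN(c3ccccc3)CC1)C(=O)N2` gives 14900 nM. Compound 2 `COc1ccc2c(c1)/C(=N/NC(=S)N1CCN(c3ccccc3)CC1)C(=O)N2` gives 14400 nM. Compound 3 `COc1ccc(N2CCN(C(=S)N/N=C3\C(=O)Nc4ccc(Cl)cc43)CC2)cc1` gives 13800 nM. The three numbers sit close together, within the usual scatter of such measurements.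

Compounds 1 and 2 differ in one place: methyl in place of methoxy on an aromatic carbon. That change gave a 1.0-fold higher number from compound 2 to compound 1 (0.01 log units; within the scatter). How the core of compound 3 differs from that of compound 2 is not broken down here.

Compound 4 `Cc1ccc(N2CCN(C(=S)N/N=C3\C(=O)Nc4ccc(Cl)cc43)CC2)cc1` has not yet been measured. It differs from compound 3 by methyl in place of methoxy on an aromatic carbon. The surroundings are not identical: in compound 2 the methoxy sits on a ring that is part of a fused or bridged system of two rings, meta to a fused ring and para to a fused ring, while in compound 3 it sits on a six-membered aromatic ring of carbon only, para to a large group. The change is therefore the same kind of change, not the same.

Because the matching change gave a 1.0-fold higher number from compound 2 to compound 1 (0.01 log units; within the scatter), the step of a 1.0-fold higher number from compound 3 to compound 4 (0.01 log units; within the scatter) is expected to be equally small. Compound 4 is estimated at 14000 nM in this assay, with a likely range from 8000 nM to 25000 nM.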

Compound 4, half-maximal inhibitory concentration: 17100 nM
For compound 4 the middle estimate is 1.2-fold (0.09 log units) below the measured one; the range from low to high includes it.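

In this assay, replacing 4-methoxyphenyl with 4-methylphenyl gave a 1.2-fold higher number from compound 3 to compound 4 (0.09 log units; within the scatter). Set beside the first case, the swap reads the same on both cores, with no measurable difference between the two steps: the same change on two cores in this assay, a 1.0-fold higher number (0.01 log units; within the scatter) from compound 2 to compound 1 and a 1.2-fold higher number (0.09 log units; within the scatter) from compound 3 to compound 4, 1.2-fold (0.08 log units) apart, within the scatter of two such steps. This shows that on these two cores the swap of methoxy for methyl leaves the number within the scatter, even though the group sits on a different part of the molecule in each pair, but it rests on just two pairs in one cell assay and does not show that the same would hold on any further core.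

From the compounds shown here alone, whether a more different group in the same place, such as an amine, a carboxylic acid or a longer chain, would give a step beyond the scatter stays open. Also open, going by these compounds, is whether such a step would then carry from one core to the other as closely as this one did.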